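Series notes: benzyloxy variation, from compound 3 to compound 4

The source may hold more compounds than are shown below. What is called first, only, known or untested is meant among the compounds shown, and "the series" means these compounds.

Three members of the series have been measured in a functional assay on thoracic aorta for antagonist activity at Alpha-1D adrenergic receptor (Rattus norvegicus); on this read-out higher numbers stand for higher potency (the scale is a negative logarithm) and lower numbers for lower potency. Compound 3 `COc1cccc(OC)c1OCCNCCOc1ccccc1OCc1ccc(C)cc1` gives 9.12, compound 1 `COc1cccc(OC)c1OCCNCCOc1ccccc1OCc1ccc(Cl)cc1` gives 9.11, and compound 2 `COc1cccc(OC)c1OCCNCCOc1ccccc1OCc1ccccc1C` gives 8.64. Compound 3 has the highest number of the three, but one gap is a number 0.01 log units higher from compound 1 to compound 3 (within the scatter), within the scatter, so those two cannot be ordered; only compound 2 is separated, by a number 0.48 log units higher from compound 2 to compound 3 (beyond the scatter).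

Compound 4 `COc1cccc(OC)c1OCCNCCOc1ccccc1OCc1ccccc1[N+](=O)[O-]` differs from compound 3 by 2-nitrophenyl in place of 4-methylphenyl on a saturated chain carbon bound to an oxygen on an aromatic ring. Among the compounds with values here, two measured steps bear on this. The 2-methylphenyl member sits lower than the 4-methylphenyl member by a number 0.48 log units higher from compound 2 to compound 3 (beyond the scatter). Swapping methyl for chloro on the same aromatic carbon moved the number by a number 0.01 log units higher from compound 1 to compound 3 (within the scatter) only. Compound 4 carries a group of a third kind, so neither step matches it closely; a modest loss in this assay, of the size seen for compound 2, is the expectation.

Compound 4 is expected to reach 8.7, between 8.2 and 9.2, a step of a number 0.42 log units lower from compound 3 to compound 4 (beyond the scatter) from compound 3.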

Compound 4, negative logarithm of the antagonist equilibrium constant: 8.95
Compound 4: the middle estimate sits 0.25 log units below what was measured, within the range that was stated.
By their numbers in this assay, from the lowest: compound 2; then compounds 4, 1 and 3 (each within the scatter of the next).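

In this assay, 2-nitrophenyl on the saturated chain carbon bound to an oxygen on an aromatic ring cannot be ordered against either 4-substituted member, neither against 4-methylphenyl (a number 0.17 log units lower from compound 3 to compound 4 (within the scatter)) nor against 4-chlorophenyl (a number 0.16 log units lower from compound 1 to compound 4 (within the scatter)). Nitro in place of methyl on the aromatic carbon does separate the two 2-substituted members (a number 0.31 log units higher from compound 2 to compound 4 (beyond the scatter)), so the lower number seen with 2-methylphenyl does not carry over to 2-nitrophenyl. Nothing available accounts for this difference between the two groups.

Open, from the compounds shown here alone, is how 4-nitrophenyl would read against 2-nitrophenyl, which would show whether the place of the nitro group matters. Also open, going by these compounds, is whether a 2-aminophenyl or 2-carboxyphenyl group would stay with compound 4 or fall towards compound 2.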